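The source may hold more compounds than are shown below. What is called first, only, known or untested is meant among the compounds shown, and "the series" means these compounds.

Measured compounds:
- compound 1, `CC(C)=CCC/C(C)=C/CC1Cc2c(OCCCNS(=O)(=O)c3ccc(Cl)cc3)cc(=O)n(CCCO)c2CC1(C)C`, in a functional assay on PANC-1 cells (Homo sapiens) for inhibition, read by MTT assay, with a stated time of 24 h, tested at 10 uM (on this read-out lower numbers stand for less inhibition and higher numbers for more inhibition at the one concentration tested (going by the name of the read-out)), compound 1 gives 14.5%
- compound 2, `CC(C)=CCC/C(C)=C/CC1Cc2c(OCCCNS(=O)(=O)c3ccc(Br)cc3)cc(=O)n(CCCO)c2CC1(C)C`, in this assay compound 2 gives 15.2%

For the measured compounds named here, of the two numbers so far, compound 2 carries the larger one on paper, yet the only step between them, a number 0.7 percentage points higher from compound 1 to compound 2 (within the scatter), lies within the scatter, so compound 1 and compound 2 cannot be told apart on this read-out. Compound 3, `COc1ccc(C(=O)NCCCOc2cc(=O)n(CCCO)c3c2CC(C/C=C(\C)CCC=C(C)C)C(C)(C)C3)cc1`, has not been measured in this assay. It differs from compound 2 in one place: (4-methoxyphenyl)carbonyl in place of (4-bromophenyl)sulfonyl on an amine nitrogen. Going by the values given here, no measured step bears on this change. Among the compounds with values here, the one step available, a number 0.7 percentage points higher from compound 1 to compound 2 (within the scatter), concerns a halogen swap on the aromatic carbon and was within the scatter; it says nothing about replacing the sulfonyl with a carbonyl or the bromo with a methoxy group. With no guidance from the data, the step of a number 0.2 percentage points lower from compound 2 to compound 3 (within the scatter) is expected to be none beyond the scatter, with a wide band of uncertainty. Compound 3 is therefore estimated at 15% in this assay, with a range from 2% to 35%.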

Compound 3, a percentage reported as inhibition, at one concentration (the size of the read-out at that concentration, not a potency): 45.7%
Compound 3: the middle estimate sits 30.7 percentage points below what was measured; the whole stated range lies below it.
By their numbers in this assay, from the lowest: compounds 1 and 2 (each within the scatter of the next); then compound 3.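

In this assay, the amine nitrogen whose other neighbour is a saturated chain carbon proved to be a place where the read-out moves: replacing (4-bromophenyl)sulfonyl with (4-methoxyphenyl)carbonyl gives a number 30.5 percentage points higher from compound 2 to compound 3 (beyond the scatter) and replacing (4-chlorophenyl)sulfonyl with the same group gives a number 31.2 percentage points higher from compound 1 to compound 3 (beyond the scatter) as large steps beyond the scatter. For the compounds shown here, the earlier pair showed only that exchanging one halogen for the other on the aromatic carbon of the sulfonyl group left the numbers within the scatter, whereas this change alters the group as a whole and is the first to separate compounds. Nothing measured on these compounds accounts for the size of this step.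

The change swaps the sulfonyl for the carbonyl and the halogen for the methoxy at once, so the compounds shown leave open which of the two goes with the higher number; a (4-methoxyphenyl)sulfonyl or a (4-bromophenyl)carbonyl on the same amine nitrogen would part them. Also open, as far as these compounds go, is whether the aromatic ring is needed at all, as an acetyl on this nitrogen would show, and, with a single concentration read, how compound 3 would behave across a range of concentrations.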